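The compounds below may be only part of what the source reports. "The series", "measured", "known", "first", "only" and "open" are said of these compounds alone.

Compound 1 `CCSC(=S)SCC(=O)c1ccc(OC)cc1`: 1960 nM
Compound 2 `CCCC(=S)SCC(=O)c1ccc(OC)cc1`: 5710 nM

Both values come from a functional assay on HeLa cells (Homo sapiens) for cytotoxicity, read by resazurin assay, with a stated time of 72 h; a lower number here means a stronger inhibitor, a higher number a weaker inhibitor. Compound 2 has the higher number of the two, which makes it the weaker inhibitor of this pair. Within the data shown here, the only measured step is a 2.9-fold higher number from compound 1 to compound 2 (0.46 log units; beyond the scatter), where propyl replaces ethylsulfanyl on a thiocarbonyl carbon.

Compound 3 `CCOC(=S)SCC(=O)c1ccc(OC)cc1` keeps the shared core and changes that same place: ethoxy in place of propyl on a thiocarbonyl carbon. This runs roughly back along the measured step, since ethoxy resembles ethylsulfanyl, with oxygen where compound 1 has sulfur. Among the measured compounds shown here, with compound 1 at 1960 nM as the only guide, a modest move towards a lower number is expected in this assay. The expected change is a 2.2-fold lower number from compound 2 to compound 3 (0.34 log units; beyond the scatter). Compound 3 is estimated at 2600 nM, within a range of 1000 nM to 6500 nM.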

Compound 3, half-maximal inhibitory concentration: 4640 nM
Compound 3: the middle estimate sits 1.8-fold (0.25 log units) below what was measured; the measured number falls inside the stated range.
By their numbers in this assay, from the lowest: compound 1; then compounds 3 and 2 (each within the scatter of the next).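

In this assay, putting ethoxy in place of propyl on a thiocarbonyl carbon gives a 1.2-fold lower number from compound 2 to compound 3 (0.09 log units; within the scatter), so these two compounds cannot be told apart here, even though ethoxy brings an oxygen and a hydrogen-bond acceptor that propyl lacks. Ethoxy and ethylsulfanyl look alike on paper, yet exchanging one for the other gives a 2.4-fold higher number from compound 1 to compound 3 (0.37 log units; beyond the scatter), so similarity on paper did not carry over to the numbers. Among these three compounds, only compound 1 stands apart, with a step beyond the scatter to each of the other two.

Going by these compounds, whether an amine or a longer chain on this thiocarbonyl carbon would shift the number, in either direction, stays open. No other measurement here bears on why compound 1 stands apart.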